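The source may hold more compounds than are shown below. What is called first, only, known or untested is meant among the compounds shown, and "the series" means these compounds.

Among the compounds with values here, in a functional assay on M21 cells (Homo sapiens) for antiproliferative activity, read by sulforhodamine B assay, with a stated time of 48 h (a higher number here means a weaker inhibitor, a lower number a stronger inhibitor), compound 2 `COc1ccc(NS(=O)(=O)c2ccc(N3CCNC3=O)cc2)cc1` gives 580 nM, the higher of the two numbers so far and therefore the weaker result, while compound 1 `Cc1ccc(NS(=O)(=O)c2ccc(N3CCNC3=O)cc2)c(C)c1` gives 150 nM. Compound 3 `Cc1ccccc1NS(=O)(=O)c1ccc(N2CCNC2=O)cc1` carries 2-methylphenyl in place of 4-methoxyphenyl on a sulfonamide nitrogen. Within the data shown here, only one measured step bears on this change: a 3.9-fold higher number from compound 1 to compound 2 (0.59 log units; beyond the scatter), where 4-methoxyphenyl replaced 2,4-dimethylphenyl at the same place. Since 2-methylphenyl is closer in name and make-up to 2,4-dimethylphenyl, a somewhat smaller step in the opposite direction is expected, a 2.1-fold lower number from compound 2 to compound 3 (0.32 log units; beyond the scatter). The estimate for compound 3 is 280 nM, with an expected range from 110 nM to 650 nM.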

Compound 3, half-maximal inhibitory concentration: 150 nM
The estimate for compound 3 lay 1.9-fold (0.27 log units) above the measured number; the range from low to high includes it.
By their numbers in this assay, from the lowest: compounds 1 and 3 (each within the scatter of the next); then compound 2.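

Replacing 4-methoxyphenyl with 2-methylphenyl on the sulfonamide nitrogen gives a 3.9-fold lower number from compound 2 to compound 3 (0.59 log units; beyond the scatter) in this assay and so recovers the whole loss seen with compound 2. Replacing one methyl of compound 1 with hydrogen on an aromatic carbon gives no change at the digits printed from compound 1 to compound 3 (within the scatter) in this comparison, so this methyl can go without a measurable cost here. The compounds shown leave open whether a plain phenyl, or a chlorine or an amine on the ring, would hold this level. No measurement here explains the gap between 2-methylphenyl and 4-methoxyphenyl.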